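This account rests on a few compounds, and the source may have more. Where it says the series, first, only, none or still open, it means among the compounds named here.

Working notes on the series. Three analogues of the shared core have been examined in a functional assay, with a stated time of 150 min, tested at 5 ug/mL; a lower number here means a weaker effect, a higher number a stronger effect of the compound at the concentration tested. Compound 1 `COC(=O)c1c(Nc2ccccc2)sc(C(=O)c2ccc(OC)cc2)c1C` gives 13.3% in this assay, a reading that lies close to the scatter of the method. Compound 2 `COC(=O)c1c(Nc2ccc(C)cc2)sc(C(=O)c2ccc(OC)cc2)c1C` is reported in this assay as "not active" (no number reported), with no number attached to the entry. Compound 3 `COC(=O)c1c(Nc2ccc(Cl)cc2)sc(C(=O)c2ccc(OC)cc2)c1C` is likewise reported in this assay as "not active" (no number reported), again without a number. Compound 2 therefore stands among the entries for which no figure is given; only compound 1 carries a measured percentage, and that one is small. Compound 4 `COC(=O)c1c(Nc2ccc(C)cc2)sc(C(=O)c2ccc(C)cc2)c1C` has not yet been measured in this assay. It differs from compound 2 by methyl in place of methoxy on an aromatic carbon. Among the compounds with values here, no measured pair in the set shares this change, so no size of step is known for it. Given that compound 2 is reported without activity and that compound 1, the only numbered entry, sits low in this assay, the expectation is for no step beyond the scatter in either direction. Compound 4 is therefore expected to show 8% in this assay, with a range from 0% to 25%, and a reasonable chance that it is again reported without a number.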

Compound 4, a percentage reported as activity, at one concentration (the size of the read-out at that concentration, not a potency): "not active" (no number reported)
For compound 4 the study gives words and no number, and the estimate cannot be compared.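

In this assay, within the data shown here, compound 2 gives "not active" (no number reported) and compound 4 gives "not active" (no number reported), so no step between them can be read. The compounds shown leave open whether going from 4-methoxyphenyl to 4-methylphenyl changes the effect in any analogue that carries a numbered reading. No supporting evidence bears on this result.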